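The source may report more compounds than this note shows. Statements on the series, on what has been measured and on what is new or still open speak of the compounds shown alone.

Measured so far in a functional assay on A549 cells (Homo sapiens) for cytotoxicity, read by MTT assay, with a stated time of 4 days; a higher number here means a weaker inhibitor, a lower number a stronger inhibitor:
compound 1 `C=C1C(=O)[C@]23C[C@@]1(O)CC[C@H]2c1ccc(O)c(C)c1[C@@H]3Cn1cc(-c2ccccc2)nn1` gives 1160 nM
compound 3 `C=C1C[C@]23C[C@@]1(O)CC[C@H]2c1ccc(O)c(C)c1[C@@H]3Cn1cc(-c2ccc(C(F)(F)F)cc2)nn1` gives 10400 nM
compound 2 `Cc1ccc(S(=O)(=O)Oc2ccc3c(c2C)[C@H](Cn2cc(-c4ccccn4)nn2)[C@@]24CC(=O)[C@@](C)(CC[C@@H]32)C4)cc1` gives only a limit, > 20000 nM

Compound 3 holds the highest of the two numbers shown in this assay; its nearest neighbour is compound 1, and the gap between the two lies beyond the scatter of repeated measurements. Compound 2 gives no number at all; its result is the limit of > 20000 nM in this assay, at which 1 of the 3 values shown sits, and is treated as a limit, not as a measurement. Among the measured compounds shown here, no pair among the measured compounds differs in one place only, so no single-change step is available within the set.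

Compound 4 `C=C1C[C@]23C[C@@]1(O)CC[C@H]2c1ccc(O)c(C)c1[C@@H]3Cn1cc(-c2ccccc2)nn1` has not yet been measured in this assay. It differs from compound 3 in one place: hydrogen in place of trifluoromethyl on an aromatic carbon. The expected step from compound 3 to compound 4 in this assay is downward, toward a stronger inhibitor, and beyond the scatter, as a 3.5-fold lower number from compound 3 to compound 4 (0.54 log units; beyond the scatter). This expectation rests on compound 1, which carries a phenyl on the triazole and gives 1160 nM in this assay. Compound 4 is therefore estimated at 3000 nM, with the expected range running from 900 nM to 10000 nM.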

Compound 4, half-maximal inhibitory concentration: > 20000 nM
Compound 4 ended at the assay's limit (the forecaster's own chance of this, stated with the estimate: 5%); middle value at least 6.6-fold (0.82 log units) away from the limit.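

In this assay the change from trifluoromethyl to hydrogen on the phenyl gives an at least 1.9-fold higher number from compound 3 to compound 4 (0.28 log units; that floor lies within the scatter) and so shows no move toward a stronger inhibitor at this position, although the floor of that step does not by itself establish a real loss. The result for compound 4 is a limit and not a number, and compound 2 stands at the same limit: the limit of > 20000 nM in this assay, at which 2 of the 4 values shown sit. Compound 4 and compound 1 both carry the phenyl on the triazole and differ in one place, a carbonyl in the core of compound 1, and compound 1 gives 1160 nM in this assay and so the unsubstituted phenyl alone does not set that number.

On these data alone, the true size of the step from trifluoromethyl to hydrogen cannot be read from a limit, and it remains open how a methoxy, an amine or a carboxylic acid in the same place on the phenyl would read. Also open, as far as these compounds go, is whether trifluoromethyl on the phenyl would read differently with the carbonyl of compound 1 kept in the core.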